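Swapping the Aryl Group on a Shared Amide Core

The compounds below may be only part of what the source reports. "The series", "measured", "known", "first", "only" and "open" are said of these compounds alone.

Of the compounds shown here, three built on the same core have been tested in an assay on LtK cells with ATP-sensitive inward rectifier potassium channel 11 (Homo sapiens) as the target; a higher number here means that more compound is needed for the effect, a lower number that less compound is needed. Compound 1 `CC(C)OC(=O)Nc1c(C(O)(C(F)(F)F)C(F)(F)F)ccc2ccccc12` carries an isopropoxy group on the carbonyl carbon, and in this assay compound 1 gives 1160 nM. Compound 2 `O=C(Nc1c(C(O)(C(F)(F)F)C(F)(F)F)ccc2ccccc12)c1ccccc1` has a phenyl group in that place and gives 44 nM. Compound 3 `Cc1cccc(C(=O)Nc2c(C(O)(C(F)(F)F)C(F)(F)F)ccc3ccccc23)c1` has a 3-methylphenyl group and gives 23 nM. Compound 3 thus holds the lowest of the three numbers, though its gap to compound 2 is within the scatter, so the two cannot be told apart. Among the compounds with values here, the changes from compound 1 stand out clearly, as seen in a 26-fold lower number from compound 1 to compound 2 (1.42 log units; beyond the scatter) and a 50-fold lower number from compound 1 to compound 3 (1.70 log units; beyond the scatter), whereas a 1.9-fold lower number from compound 2 to compound 3 (0.28 log units; within the scatter) is the one step that bears directly on what comes next.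

Compound 4 `O=C(Nc1c(C(O)(C(F)(F)F)C(F)(F)F)ccc2ccccc12)c1ccc(F)cc1` is not yet measured. Its change from compound 3 is 4-fluorophenyl in place of 3-methylphenyl on a carbonyl carbon. The exchange keeps a six-membered aromatic ring on the carbonyl carbon, much as compound 2 has. Within the data shown here, since the methyl group shifted the number only within the scatter in a 1.9-fold lower number from compound 2 to compound 3 (0.28 log units; within the scatter), and no measured compound shows what a fluorine does here, compound 4 is expected to show a 1.7-fold higher number from compound 3 to compound 4 (0.24 log units; within the scatter). For compound 4 in this assay the estimated value is 40 nM, with a range from 15 nM to 110 nM.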

Compound 4, half-maximal effective concentration: 70 nM
The estimate for compound 4 lay 1.8-fold (0.24 log units) below the measured number; low and high end bracket the measured number.
By their numbers in this assay, from the lowest: compounds 3, 2 and 4 (each within the scatter of the next, the first and the last beyond it); then compound 1.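

Set against the plain phenyl of compound 2, the 4-fluorophenyl group gives a 1.6-fold higher number from compound 2 to compound 4 (0.20 log units; within the scatter) in this assay and so cannot be told apart from it, which means a fluoro group in place of hydrogen on this ring leaves the number where it was within the scatter. Within the data shown here, the comparison between the two substituted rings reads differently: a 3.0-fold higher number from compound 3 to compound 4 (0.48 log units; beyond the scatter) and is the first step among the compounds with an aromatic ring on the carbonyl carbon to lie beyond the scatter, so 3-methylphenyl and 4-fluorophenyl can be separated here even though neither can be separated from phenyl. The large difference from the isopropoxy compound also holds for this third ring, with a 17-fold lower number from compound 1 to compound 4 (1.22 log units; beyond the scatter) as the step, so compounds 2, 3 and 4 all sit far from compound 1 in the same direction.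

As far as these compounds go, what stays open is whether the gap between compound 3 and compound 4 follows from the kind of group or from where it sits, a question that a 4-methylphenyl or a 3-fluorophenyl group would address, and how a ring carrying an amine or a carboxylic acid would behave at this position. No measurement at hand explains why these numbers fall as they do.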